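Adding a Methyl Branch Near the Acid-Bearing Ring

The compounds below may be only part of what the source reports. "The series", "measured", "known", "first", "only" and "open" are said of these compounds alone.

Compound 1: `CN(Cc1cccc(C(=O)O)c1)c1ccc(OCc2c(-c3c(Cl)cccc3Cl)noc2C2CC2)nc1C(F)(F)F` gives 102%
Compound 2: `O=C(O)c1cccc(OCc2ccc(OCc3c(-c4c(Cl)cccc4Cl)noc3C3CC3)nc2C(F)(F)F)c1` gives 98%

Both compounds were tested in an assay on isolated protein for agonist activity at Bile acid receptor (Homo sapiens), read by FRET; a lower number here means a smaller maximal response, a higher number a larger maximal response. Compound 1 reaches 102%, while compound 2 reaches 98%. For the measured compounds named here, the one measured step, a number 4 percentage points lower from compound 1 to compound 2 (within the scatter), lies within the scatter, so the two numbers cannot be told apart. Going by the values given here, compound 2 holds the lower of the two numbers, but its only neighbour, compound 1, sits within the scatter of it, so nothing can be said about which of them is stronger.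

Compound 3, `CC(Oc1cccc(C(=O)O)c1)c1ccc(OCc2c(-c3c(Cl)cccc3Cl)noc2C2CC2)nc1C(F)(F)F`, is the next compound. It differs from compound 2 by methyl in place of hydrogen on a saturated chain carbon bound to an aromatic carbon and an oxygen on an aromatic ring. Cut one bond further out, the same difference reads (3-carboxyphenoxy)methyl to 1-(3-carboxyphenoxy)ethyl. Among the compounds with values here, no measured step concerns this kind of change; the only step available, a number 4 percentage points lower from compound 1 to compound 2 (within the scatter), exchanges a whole linking group and still stays within the scatter. With a full response preserved across that larger change, the expectation for compound 3 is a step of a number 2 percentage points lower from compound 2 to compound 3 (within the scatter), nothing beyond the scatter. Compound 3 is therefore estimated at 96%, with a range from 78% to 110%.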

Compound 3, largest response reached (reported as efficacy), in percent of the reference or control that the assay uses: 102%
For compound 3 the middle estimate is 6 percentage points below the measured one; measured number inside the range.
By their numbers in this assay, from the lowest: compounds 2, 1 and 3 (each within the scatter of the next).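

In this assay, a methyl on the saturated chain carbon bound to an aromatic carbon and an oxygen, which turns (3-carboxyphenoxy)methyl into 1-(3-carboxyphenoxy)ethyl, gives a number 4 percentage points higher from compound 2 to compound 3 (within the scatter), so this carbon can carry a small branch with the maximal response still indistinguishable from that of the unbranched compound. For the compounds shown here, the earlier pair showed only that one whole linking group could replace another; this result is the first look at a single added carbon within the link itself. Set against the original link, the branched one gives no change at the digits printed from compound 1 to compound 3 (within the scatter), so all three links reach maximal responses that cannot be told apart, and no measurement at hand bears on why the response holds at this carbon.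

A maximal response describes only how far the receptor is driven, so these numbers leave open whether the methyl changes the amount of compound needed to reach it. Also open is how much this carbon tolerates: an ethyl, a cyclopropyl or a hydroxyl group there could keep the response or lose it, and the compounds shown cannot tell which.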